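The compounds below may be only part of what the source reports. "The series", "measured", "known", "first", "only" and "open" are said of these compounds alone.

In an assay for inhibition of S-adenosylmethionine decarboxylase proenzyme (Rattus norvegicus) (on this read-out higher numbers stand for weaker inhibition and lower numbers for stronger inhibition), the three measured compounds give three clearly separated numbers. Compound 2 `N=C(N)N/N=C/c1cccc(C(=N)N)n1` gives 90 nM, the lowest of the three. Compound 1 `N=C(NN)N/N=C/c1cccc(C(=N)N)c1` gives 210 nM, and compound 3 `N=C(N)N/N=C/c1cccc(C(=N)NO)n1` gives 25000 nM.

The unmeasured compound 4 `N=C(NN)N/N=C/c1cccc(C(=N)N)n1` differs from compound 2 by amino in place of hydrogen on an amine nitrogen. For the measured compounds named here, compound 1 also carries this aminoamino group, but it differs from compound 2 in a second place as well, so its number alone cannot show what the single change does; its value sits only somewhat above that of compound 2. Going by the values given here, the one single-point step that is known, a 280-fold higher number from compound 2 to compound 3 (2.44 log units; beyond the scatter), concerns a different amine nitrogen and a different entering group, so it does not bear directly on the change to compound 4.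

With this thin basis, a step of no great size is expected from compound 2 to compound 4, leaning slightly towards a higher number, a 1.7-fold higher number from compound 2 to compound 4 (0.22 log units; within the scatter). Compound 4 is therefore estimated at 150 nM, within a range of 50 nM to 500 nM.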

Compound 4, half-maximal inhibitory concentration: 670 nM
For compound 4 the middle estimate is 4.5-fold (0.65 log units) below the measured one, and the stated range ends below it.
By their numbers in this assay, from the lowest: compound 2; then compound 1; then compound 4; then compound 3.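

In this assay, the new compound isolates the change, and amino in place of hydrogen on this amine nitrogen gives a real loss of inhibition: the number rises in a 7.4-fold higher number from compound 2 to compound 4 (0.87 log units; beyond the scatter). For the compounds shown here, compound 1 could not show this, as it differs from compound 2 in a second place as well, so this is the first direct reading of what the amino group does at this nitrogen, whose other neighbour is a carbon with a double bond to nitrogen. Nothing available explains why the number rises.

From the compounds shown here alone, whether a methyl group or a longer chain on this nitrogen would raise the number as far stays open. Equally open, going by these compounds, is what hydrogen in place of the amino group would do on the core of compound 1.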